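Swapping bromine for chlorine at the edge of a weak compound

The source may hold more compounds than are shown below. What is called first, only, known or untested is meant among the compounds shown, and "the series" means these compounds.

Compound 1, `S=C(N/N=C/c1ccc2ccccc2n1)Nc1ccc(Br)cc1`, is a thiosemicarbazone bearing a bromo group on its outer phenyl ring. In a functional assay on HeLa cells (Homo sapiens) for antiproliferative activity, read by sulforhodamine B assay, with a stated time of 72 h (a higher number here means a weaker inhibitor, a lower number a stronger inhibitor), compound 1 gives 56800 nM, the highest number of the three measured here. Compound 2, `CC(C)c1cccc(C(C)C)c1NC(=S)N/N=C/c1ccc2ccccc2n1`, gives 16400 nM, and compound 3, `CN(C)C(=S)N/N=C/c1ccc2cccnc2n1`, gives 970 nM; both steps down from compound 1 lie beyond the scatter, so compound 1 is the weakest of the three. Compound 4, `S=C(N/N=C/c1ccc2ccccc2n1)Nc1ccc(Cl)cc1`, differs from compound 1 in one place: chloro in place of bromo on an aromatic carbon. Going by the values given here, no measured pair shows this change, so the expected step of a 1.1-fold higher number from compound 1 to compound 4 (0.02 log units; within the scatter) is small and may fall within the scatter. Compound 4 is therefore expected to give about 60000 nM, in a range from 25000 nM to 140000 nM.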

Compound 4, half-maximal inhibitory concentration: > 100000 nM
Compound 4: no number, only a limit (the forecaster's own chance of this, stated with the estimate: 10%); middle value at least 1.6-fold (0.22 log units) from the limit.
By their numbers in this assay, from the lowest: compound 3; then compound 2; then compound 1. At a limit, above all of these: compound 4.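

In this assay compound 4 gives > 100000 nM, which is a limit of the assay and not a number. The step from 4-bromophenyl to 4-chlorophenyl reads an at least 1.7-fold higher number from compound 1 to compound 4 (0.24 log units; that floor lies within the scatter), so chloro brings no visible gain over bromo on this aromatic carbon. The full size of the step cannot be read, because the value of compound 4 is only a limit: the limit of > 100000 nM in this assay, at which 1 of the 4 values shown sits.

On these data alone, whether an amine or a carboxylic acid at this position would lower the number remains open. So does whether the same swap of bromo for chloro would behave alike on a different core.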